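Hydroxycarbamoyl chain series: the step to compound 4

A few compounds are considered here, and "the series" means these few. Any claim that something is new, unique, unknown or untested is made for them only; others in the source may bear on it.

In a functional assay on NCI-H1975 cells (Homo sapiens) for inhibition, read by sulforhodamine B assay, with a stated time of 48 h (a higher number here means a weaker inhibitor of growth, a lower number a stronger inhibitor of growth), compound 1 `CC(C)c1cc(C(=O)N(C)c2ccc(NC(=O)CCCCCCCCC(=O)NO)cc2)c(O)cc1O` gives 210 nM, compound 2 `CC(C)c1cc(C(=O)N(C)c2ccc(NC(=O)CCCCCCCC(=O)NO)cc2)c(O)cc1O` gives 400 nM and compound 3 `CC(C)c1cc(C(=O)N(C)c2ccc(NC(=O)CCCCCCC(=O)NO)cc2)c(O)cc1O` gives 690 nM. Compound 3 thus lies within the scatter of compound 2 and beyond the scatter of compound 1.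

Compound 4 `CC(C)c1cc(C(=O)N(C)c2ccc(NC(=O)CCCCCC(=O)NO)cc2)c(O)cc1O` differs from compound 3 as follows: hydroxycarbamoyl in place of (hydroxycarbamoyl)methyl on a saturated chain carbon, five bonds along the chain from a carbonyl carbon. The same kind of change has been measured in this series. For the measured compounds named here, the single steps are a 1.9-fold higher number from compound 1 to compound 2 (0.28 log units; within the scatter) and a 1.7-fold higher number from compound 2 to compound 3 (0.24 log units; within the scatter), both within the scatter. Taken together they give a 3.3-fold higher number from compound 1 to compound 3 (0.52 log units; beyond the scatter), which is beyond the scatter but modest. Both single steps point the same way, and none of the three compounds goes against this trend, though the trend rests on those compounds alone.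

One more small move towards a higher number in this assay is therefore expected. The expected step is a 1.7-fold higher number from compound 3 to compound 4 (0.24 log units; within the scatter). For compound 4 the estimated value is 1200 nM, with an expected range of 650 nM to 2300 nM.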

Compound 4, concentration for 50% growth inhibition: 690 nM
Compound 4: middle estimate off by 1.7-fold (0.24 log units), on the high side, within the range that was stated.
By their numbers in this assay, from the lowest: compounds 1, 2, 3 and 4 (each within the scatter of the next, the first and the last beyond it).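

In this assay, hydroxycarbamoyl in place of (hydroxycarbamoyl)methyl, five bonds along the chain from a carbonyl carbon, gives no change at the digits printed from compound 3 to compound 4 (within the scatter), so the same-direction run of single steps among compounds 1, 2 and 3 does not extend to this step. The wider comparisons read a 1.7-fold higher number from compound 2 to compound 4 (0.24 log units; within the scatter) and a 3.3-fold higher number from compound 1 to compound 4 (0.52 log units; beyond the scatter); only the second lies beyond the scatter, and it matches the step already seen a 3.3-fold higher number from compound 1 to compound 3 (0.52 log units; beyond the scatter). The same change, read at two places in the chain, gives steps that agree within the scatter: the same change on two cores in this assay, a 1.9-fold higher number (0.28 log units; within the scatter) from compound 1 to compound 2 and no change at the digits printed (within the scatter) from compound 3 to compound 4, 1.9-fold (0.28 log units) apart, within the scatter of two such steps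

The compounds shown leave open whether a chain shorter than that of compound 4, or one longer than that of compound 1, would give a step beyond the scatter. They also leave open how a carboxylic acid in place of hydroxycarbamoyl would read in this assay.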